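Compound 4: 3-chlorophenyl in place of 4-chlorophenyl

The source may hold more compounds than are shown below. What is called first, only, known or untested is meant among the compounds shown, and "the series" means these compounds.

Three compounds of the series have numbers in an assay on isolated protein for inhibition of protein kinase C zeta type (Homo sapiens), read by 33P incorporation, tested at 200 uM; a lower number here means a weaker effect, a higher number a stronger effect of the compound at the concentration tested. Compound 1 `O=C(O)CC(Cc1nc2cc(Cl)ccc2[nH]1)c1ccc(Cl)cc1` gives 70% and stands highest of the three. Compound 2 `O=C(O)CC(Cc1nc2cc(F)ccc2[nH]1)c1ccc(Cl)cc1` gives 30%, and compound 3 `COC(=O)c1ccc2[nH]c(CC(CC(=O)O)c3ccc(Cl)cc3)nc2c1` gives 0%. Every measured step exchanges the substituent on an aromatic carbon of the shared core: a number 40 percentage points lower from compound 1 to compound 2 (beyond the scatter), a number 70 percentage points lower from compound 1 to compound 3 (beyond the scatter) and a number 30 percentage points lower from compound 2 to compound 3 (beyond the scatter). Each of these is beyond the scatter, and compound 1 sits clearly above both of the others.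

Compound 4 `O=C(O)CC(Cc1nc2cc(Cl)ccc2[nH]1)c1cccc(Cl)c1` is not yet measured. It differs from compound 1 in this way: 3-chlorophenyl in place of 4-chlorophenyl on a saturated chain carbon bound to two saturated chain carbons. The two have the same atoms, joined differently. None of the three measured steps touches the chlorophenyl; all of them concern the substituent on the shared core, so they show how strongly that substituent matters but say nothing about the chlorophenyl. For the measured compounds named here, for the step from compound 1 to compound 4 in this assay there is therefore no measured precedent, and no step beyond the scatter is expected in either direction, although the spread around that expectation is wide. Compound 4 is expected to give 60%, with a range from 30% to 85%, which means an expected step of a number 10 percentage points lower from compound 1 to compound 4 (within the scatter).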

Compound 4, a percentage reported as inhibition, at one concentration (the size of the read-out at that concentration, not a potency): 0%
Beside the measured number, compound 4's estimate is 60 percentage points above it, and the stated range ends above it.
By their numbers in this assay, from the lowest: compounds 3 and 4 (each within the scatter of the next); then compound 2; then compound 1.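

In this assay, for the compounds shown here, 3-chlorophenyl in place of 4-chlorophenyl on the saturated chain carbon bound to two saturated chain carbons gives a number 70 percentage points lower from compound 1 to compound 4 (beyond the scatter), so the chlorophenyl matters as well as the substituent on the shared core, the only place changed in the earlier steps. Compound 1 and compound 4 have the same atoms, and both groups have the same heavy-atom, donor and acceptor counts, so the way the chlorophenyl is joined is the only difference between them; keeping chloro on the core does not by itself preserve the effect, since compound 4 gives 0%. No measured property of these compounds bears on the reason for this step.

The compounds shown leave open whether the effect depends on chloro itself or on any group in that place, which an unsubstituted phenyl, 4-fluorophenyl or 4-methoxyphenyl on the same chain carbon would help to separate. Also open, going by these compounds, is whether 3-chlorophenyl has the same effect with fluoro on the core, as in compound 2, or whether the two changes depend on each other.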